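Working notes: substituting the piperidin-1-yl of compound 1

A few compounds are considered here, and "the series" means these few. Any claim that something is new, unique, unknown or untested is made for them only; others in the source may bear on it.

Measured in an in vitro ADME assay on microsomes from liver (Rattus norvegicus) for metabolic stability; on this read-out higher numbers stand for fast clearance and lower numbers for slow clearance:
- compound 1 `CC(C)NC(=O)[C@H]1CC[C@@H](n2/c(=N/C(=O)c3ccccc3)[nH]c3ccc(CN4CCCCC4)cc32)CC1`: 389 mL.min-1.g-1
- compound 2 `C=CCNS(=O)(=O)c1cccc(C(=O)/N=c2\[nH]c3cc(CN4CCCCC4)ccc3n2[C@H]2CC[C@@H](CO)CC2)c1`: 314 mL.min-1.g-1
- compound 3 `CCNC(=O)[C@H]1CC[C@@H](n2/c(=N/C(=O)c3ccccc3)[nH]c3ccc(CN4CCCCC4)cc32)CC1`: 310 mL.min-1.g-1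

In this assay compound 1 stands within the scatter of both compound 2 and compound 3, so no order can be read among them. Compound 4 `CC(C)NC(=O)[C@H]1CC[C@@H](n2/c(=N/C(=O)c3ccccc3)[nH]c3ccc(CN4CCC(C(C)(C)O)CC4)cc32)CC1` differs from compound 1 by 1-hydroxy-1-methylethyl in place of hydrogen on a saturated ring carbon, which turns piperidin-1-yl into 4-(1-hydroxy-1-methylethyl)piperidin-1-yl. Among the measured compounds shown here, the only measured step, a 1.3-fold lower number from compound 1 to compound 3 (0.10 log units; within the scatter), lies elsewhere in the molecule, and no measured step covers this change. Its size and direction are therefore poorly supported, and a wide range is needed. The estimated step is a 1.6-fold lower number from compound 1 to compound 4 (0.19 log units; within the scatter), which is expected to stay within the scatter. For compound 4 the expected value is 250 mL.min-1.g-1, with an estimated range of 100 mL.min-1.g-1 to 450 mL.min-1.g-1.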

Compound 4, intrinsic clearance in microsomes: 21 mL.min-1.g-1
Beside the measured number, compound 4's estimate is 12-fold (1.08 log units) above it; measured number outside the range, below it.
By their numbers in this assay, from the lowest: compound 4; then compounds 3, 2 and 1 (each within the scatter of the next).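

Substitution at this ring carbon, three ring bonds from the ring nitrogen, is far from neutral in this assay: 1-hydroxy-1-methylethyl in place of hydrogen gives a 19-fold lower number from compound 1 to compound 4 (1.27 log units; beyond the scatter), the first step in the series beyond the scatter. The earlier step on the amide side chain, a 1.3-fold lower number from compound 1 to compound 3 (0.10 log units; within the scatter), gave no sign of a change this large. No supporting measurement bears on why the number moves so far.

Still open, on these data alone, is whether a plain methyl, a methoxy or a carboxylic acid on the same ring carbon gives a step of similar size. Also open, as far as these compounds go, is whether 1-hydroxy-1-methylethyl carries the same step over to compound 2 or compound 3.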